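From 4-bromophenyl to 4-aminophenyl

A few compounds are considered here, and "the series" means these few. Any claim that something is new, unique, unknown or untested is made for them only; others in the source may bear on it.

In a functional assay on MCF7 cells (Homo sapiens) for cytotoxicity, read by MTT assay, with a stated time of 96 h (on this read-out higher numbers stand for weaker inhibition and lower numbers for stronger inhibition), compound 1 `COc1ccccc1-n1cc(C(=O)c2cc(OC)c(OC)c(OC)c2)c(-c2ccccc2)c1` gives 150 nM and compound 2 `COc1cc(C(=O)c2cn(-c3ccc(Br)cc3)cc2-c2ccccc2)cc(OC)c1OC` gives 20 nM, the lower of the two numbers. Compound 3 `COc1cc(C(=O)c2cn(-c3ccc(N)cc3)cc2-c2ccccc2)cc(OC)c1OC` departs from compound 2 at one place: amino in place of bromo on an aromatic carbon. This is amino in place of bromo on an aromatic carbon, para to a large group.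

Going by the values given here, only one measured step bears on this change: a 7.5-fold lower number from compound 1 to compound 2 (0.88 log units; beyond the scatter). Among the compounds with values here, that step shows that the aromatic group on nitrogen can move the number beyond the scatter, but it gives only indirect guidance, and no amino compound has been measured yet. No step beyond the scatter is therefore expected, with a slight lean towards a higher number and a wide margin on both sides. The expected step is a 1.3-fold higher number from compound 2 to compound 3 (0.10 log units; within the scatter). Compound 3 is estimated at 25 nM, within an expected range of 6 nM to 100 nM.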

Compound 3, half-maximal inhibitory concentration: 35 nM
The estimate for compound 3 lay 1.4-fold (0.15 log units) below the measured number, within the range that was stated.
By their numbers in this assay, from the lowest: compounds 2 and 3 (each within the scatter of the next); then compound 1.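

In this assay, exchanging bromo for amino at this place gives no step beyond the scatter: a 1.8-fold higher number from compound 2 to compound 3 (0.24 log units; within the scatter). The step beyond the scatter seen for 4-bromophenyl over 2-methoxyphenyl on the aromatic nitrogen also appears with a second group para to a large group, a 4.3-fold lower number from compound 1 to compound 3 (0.63 log units; beyond the scatter), so in these three compounds it does not depend on bromo alone. No measurement accompanying these compounds accounts for either step.

How a hydroxyl, a carboxylic acid or an acetamide would read on the same aromatic carbon remains an open question, so the range of groups accepted at this place is still undefined. As far as these compounds go, whether the methoxy group itself or its place on the ring separates compound 1 from compound 2 and compound 3 also stays open.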